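Fluoro to bromomethyl: the next step in the series

This account rests on a few compounds, and the source may have more. Where it says the series, first, only, none or still open, it means among the compounds named here.

Measured so far in a functional assay on KBVIN cells (Homo sapiens) for antiproliferative activity, read by sulforhodamine B assay, with a stated time of 3 days; on this read-out higher numbers stand for an effect only at larger amounts of compound and lower numbers for an effect already at smaller amounts
- compound 1 (`CCC1=C(O)c2c(oc(-c3ccc(C)cc3)cc2=O)C(CC)(CC)C1=O`) gives 0.08 uM
- compound 2 (`CCC1=C(O)c2c(oc(-c3ccc(F)cc3)cc2=O)C(CC)(CC)C1=O`) gives 1.85 uM

Compound 2 holds the higher of the two numbers. Compound 3 (`CCC1=C(O)c2c(oc(-c3ccc(CBr)cc3)cc2=O)C(CC)(CC)C1=O`), not yet measured, has bromomethyl in place of fluoro on an aromatic carbon. Among the measured compounds shown here, the only measured step at this place is large (a 23-fold higher number from compound 1 to compound 2 (1.36 log units; beyond the scatter)), with fluoro in place of methyl. Bromomethyl, like methyl, is attached through carbon, but no bromine-bearing compound has been measured, so only a partial return is expected in this assay (a 6.2-fold lower number from compound 2 to compound 3 (0.79 log units; beyond the scatter)), towards a lower number. Compound 3 is estimated at 0.3 uM (range 0.05 uM to 1.5 uM).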

Compound 3, concentration for half-maximal effect: 27.9 uM
Beside the measured number, compound 3's estimate is 93-fold (1.97 log units) below it, and the stated range ends below it.
By their numbers in this assay, from the lowest: compound 1; then compound 2; then compound 3.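

In this assay attachment through carbon alone does not hold the low number: bromo in place of hydrogen on the saturated chain carbon gives a 350-fold higher number from compound 1 to compound 3 (2.54 log units; beyond the scatter) at this place on the aromatic ring. Fluoro does not mark the high end of the numbers either, since a 15-fold higher number from compound 2 to compound 3 (1.18 log units; beyond the scatter) follows on going to bromomethyl, so the two carbon-attached groups fall on either side of fluoro. No evidence at hand bears on these steps.

Still open, going by these compounds, is whether hydroxymethyl, aminomethyl or a longer chain such as ethyl at this place stays near compound 1 or near compound 3. Chloro or bromo directly on the aromatic carbon would also show whether bromine itself tracks with the high number.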